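A few compounds are considered here, and "the series" means these few. Any claim that something is new, unique, unknown or untested is made for them only; others in the source may bear on it.

Compound 1 `Cc1cnc(N2CCC(c3coc4c(N5CCc6cc(S(C)(=O)=O)ccc65)ncnc34)CC2)nc1` — 252 nM
Compound 2 `CC(C)(C)OC(=O)N1CCC(c2coc3c(N4CCCc5cc(S(C)(=O)=O)ccc54)ncnc23)CC1` — 793 nM

Both were read in a functional assay on cells for agonist activity at Glucose-dependent insulinotropic receptor (Homo sapiens), read by a luciferase reporter, with a stated time of 4 h; a lower number here means that less compound is needed, a higher number that more compound is needed for the effect. Compound 1 holds the lowest of the two numbers; compound 2 sits higher by a margin beyond the usual scatter. Going by the values given here, no pair of measured compounds differs in a single place, so no measured step exists to lean on. Compound 3 `CCc1cnc(N2CCC(c3coc4c(N5CCc6cc(S(C)(=O)=O)ccc65)ncnc34)CC2)nc1` differs from compound 1 by methyl in place of hydrogen on a saturated chain carbon bound to an aromatic carbon. Among the compounds with values here, with no comparable step measured, no move beyond the scatter is expected in this assay, in either direction. For compound 3 the expected value is 250 nM, with a range from 100 nM to 630 nM. The step of a 1.0-fold lower number from compound 1 to compound 3 (0.00 log units; within the scatter) is thus expected to stay within the scatter.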

Compound 3, half-maximal effective concentration: 41 nM
The estimate for compound 3 lay 6.1-fold (0.79 log units) above the measured number; measured number outside the range, below it.
By their numbers in this assay, from the lowest: compound 3; then compound 1; then compound 2.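

In this assay, going by these compounds alone, the change from 5-methylpyrimidin-2-yl to 5-ethylpyrimidin-2-yl gives a 6.1-fold lower number from compound 1 to compound 3 (0.79 log units; beyond the scatter), the only measured single-place step, and it lies beyond the scatter. This place on the chain is therefore sensitive: adding 1 carbon is enough to lower the number. Nothing measured here explains the step. As far as these compounds go, whether a propyl chain or a cyclopropyl ring at this place lowers the number further remains open, as does whether a methoxy group or a chlorine atom could replace ethyl.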